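Naphthyl to methoxyphenyl swap in the triazole-linked series

The source may report more compounds than this note shows. Statements on the series, on what has been measured and on what is new or still open speak of the compounds shown alone.

Values below come from a functional assay on THP-1 cells (Homo sapiens) for inhibition, read by sulforhodamine B assay, with a stated time of 48 h, tested at 50 uM (a lower number here means less inhibition of growth, a higher number more inhibition of growth at the concentration tested), and nothing else.
- compound 1 `COc1cc(/C=C/C(=O)/C=C/c2cccc3ccccc23)ccc1OCc1cn(CCCOc2cc(=O)oc3ccccc23)nn1` gives 71%
- compound 2 `COc1cccc(/C=C/C(=O)/C=C/c2ccc(OCc3cn(CCOc4cc(=O)oc5ccccc45)nn3)c(OC)c2)c1` gives 77%
- compound 3 `COc1cc(/C=C/C(=O)/C=C/c2cc(OC)c(OC)c(OC)c2)ccc1OCc1cn(CCCCOc2cc(=O)oc3ccccc23)nn1` gives 65%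

Compound 1 sits in the middle of these numbers, within the scatter of each of the other two. Compound 4 `COc1ccc(/C=C/C(=O)/C=C/c2ccc(OCc3cn(CCCOc4cc(=O)oc5ccccc45)nn3)c(OC)c2)cc1` is not yet measured. It places 4-methoxyphenyl where compound 1 has naphthalen-1-yl, on a double-bonded chain carbon bound to a double-bonded chain carbon: 4-methoxyphenyl in place of naphthalen-1-yl on a double-bonded chain carbon bound to a double-bonded chain carbon is the whole change.

Within the data shown here, no measured pair isolates a single change. Compound 2 at 77% and compound 3 at 65% carry other groups at that place, so no step beyond the scatter is expected in this assay here. The estimated step of a number 1 percentage points higher from compound 1 to compound 4 (within the scatter) is expected to stay small. For compound 4 the expected value is 72% with an estimated range of 60% to 84% as the likely span.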

Compound 4, percent growth inhibition at one concentration: 56%
Compound 4: the middle estimate sits 16 percentage points above what was measured, and the stated range ends above it.
By their numbers in this assay, from the lowest: compounds 4, 3, 1 and 2 (each within the scatter of the next, the first and the last beyond it).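

In this assay, among these compounds, the place on a double-bonded chain carbon bound to a double-bonded chain carbon responds to the group it carries: 4-methoxyphenyl in place of naphthalen-1-yl gives a number 15 percentage points lower from compound 1 to compound 4 (beyond the scatter) as the only single-place step. The change removes one six-membered aromatic ring of carbon only and adds one hydrogen-bond acceptor, and this one pair cannot separate the two. Nothing available explains the step.

On these data alone, whether a 4-(dimethylamino)phenyl group here would stay nearer compound 1 or compound 4 remains open. Steps involving compound 2 and compound 3 cannot be read, since each differs from the others in more than one place.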